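The source may report more compounds than this note shows. Statements on the series, on what has been measured and on what is new or still open speak of the compounds shown alone.

Series on the shared core of compound 1 `O=C(O)c1cc(-c2cccc(COc3ccc4c(c3)CN(c3ccccc3)C4=O)c2)ccc1Cl`, varied on the amide-type nitrogen in a ring. In an assay on HEK293 cells for positive allosteric modulation of metabotropic glutamate receptor 2 (Rattus norvegicus), read by thallium flux (a higher number here means that more compound is needed for the effect, a lower number that less compound is needed), compound 1 gives 260 nM. Compound 2 `CC(C)CCN1Cc2cc(OCc3cccc(-c4ccc(Cl)c(C(=O)O)c4)c3)ccc2C1=O`, the isopentyl analogue, gives 60 nM in this assay, a step of a 4.3-fold lower number from compound 1 to compound 2 (0.64 log units; beyond the scatter). Compound 3 `CCCN1Cc2cc(OCc3cccc(-c4ccc(Cl)c(C(=O)O)c4)c3)ccc2C1=O` carries propyl at the same nitrogen; in this assay compound 3 reaches only the limit of the measurement, > 10000 nM, so compound 3 stands at the limit of > 10000 nM in this assay, at which 1 of the 3 values shown sits, and is the weakest of the three measured compounds. The steps into it are large: an at least 38-fold higher number from compound 1 to compound 3 (1.58 log units; beyond the scatter) and an at least 160-fold higher number from compound 2 to compound 3 (2.22 log units; beyond the scatter).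

Compound 4 `O=C(O)c1cc(-c2cccc(COc3ccc4c(c3)CN(C3CCCCC3)C4=O)c2)ccc1Cl` is compound 3 with the change (cyclohexyl in place of propyl on an amide-type nitrogen in a ring). Both measured steps that bear on it, from phenyl and from isopentyl to the propyl of compound 3, were large and upward in this assay; cyclohexyl returns to a group of the size of phenyl or isopentyl, so a large step downward in this assay is expected for compound 4, of about an at least 33-fold lower number from compound 3 to compound 4 (1.52 log units; beyond the scatter). Compound 4 is therefore estimated at 300 nM in this assay, with a range of 60 nM to 3000 nM.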

Compound 4, half-maximal effective concentration: 270 nM
Compound 4: the middle estimate sits 1.1-fold (0.05 log units) above what was measured; the measured number falls inside the stated range.
By their numbers in this assay, from the lowest: compound 2; then compounds 1 and 4 (each within the scatter of the next). At a limit, above all of these: compound 3.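

In this assay, cyclohexyl and phenyl on the amide-type nitrogen in a ring cannot be told apart (a 1.0-fold higher number from compound 1 to compound 4 (0.02 log units; within the scatter)), so a non-aromatic ring of carbon only serves here as well as phenyl does. The propyl of compound 3 is the outlier among these groups, since cyclohexyl restores a large part of the loss (an at least 37-fold lower number from compound 3 to compound 4 (1.56 log units; beyond the scatter)), yet isopentyl still holds the lowest number of the four (a 4.5-fold higher number from compound 2 to compound 4 (0.65 log units; beyond the scatter)). Compound 3 remains alone at a limit: the limit of > 10000 nM in this assay, at which 1 of the 4 values shown sits.

Going by these compounds, what a straight butyl or longer chain would give at this nitrogen stays open, so the gap between propyl and isopentyl has no intermediate. Also open, on these data alone, is whether a cyclopentyl ring, or a ring carrying an amine, would be accepted in place of cyclohexyl.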